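The source may report more compounds than this note shows. Statements on the series, on what has been measured and on what is new or still open speak of the compounds shown alone.

Compound 3 `O=c1nc2oc(CCCCl)cc2cn1Cc1cn(-c2ccccc2F)nn1` stands at the top of the two numbers shown in a functional assay on A549 cells (Homo sapiens) for antiproliferative activity, read by MTT assay, with a stated time of 72 h (a higher number here means a weaker inhibitor, a lower number a stronger inhibitor), where compound 3 gives 69800 nM. Its nearest neighbour is compound 1 `O=c1nc2oc(C3CC3)c(C#CC3CC3)c2cn1Cc1cn(-c2ccccc2F)nn1`, which in this assay gives 38300 nM, a gap that lies within the scatter. Compound 2 `CCCCCCc1cc2cn(Cc3cn(-c4ccccc4F)nn3)c(=O)nc2o1` in this assay gives only a limit, > 100000 nM. Among the compounds with values here, the single measured step, an at least 1.4-fold lower number from compound 2 to compound 3 (0.15 log units; that floor lies within the scatter), changes the chain on the shared core and stays within the scatter. Compound 4 `O=c1nc2oc(CCCCl)cc2cn1Cc1cn(-c2ccc(Cl)cc2)nn1` differs from compound 3 at another place: 4-chlorophenyl in place of 2-fluorophenyl on an aromatic nitrogen. Within the data shown here, no measured step touches that ring, so no change beyond the scatter is expected. Compound 4 is therefore estimated to give 70000 nM in this assay, between 30000 nM and 150000 nM, which is expected to mean a 1.0-fold higher number from compound 3 to compound 4 (0.00 log units; within the scatter).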

Compound 4, half-maximal inhibitory concentration: 52000 nM
Compound 4: middle estimate off by 1.3-fold (0.13 log units), on the high side; the range from low to high includes it.
By their numbers in this assay, from the lowest: compounds 1, 4 and 3 (each within the scatter of the next). At a limit, above all of these: compound 2.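

In this assay, within the data shown here, the first measured change at this ring, 4-chlorophenyl in place of 2-fluorophenyl on an aromatic nitrogen, gives a 1.3-fold lower number from compound 3 to compound 4 (0.13 log units; within the scatter). Exchanging one halogen-bearing phenyl for the other therefore does not separate these two compounds, although that rests on a single pair with a single chain. Nothing measured here speaks to a cause for so small a step. Going by these compounds, whether a phenyl carrying an amine or a carboxylic acid would move the number beyond the scatter stays open. So does whether the same exchange would behave alike on the core of compound 1.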